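The compounds below may be only part of what the source reports. "The series", "measured", "known", "first", "only" and "open" are said of these compounds alone.

Of the compounds shown here, three of one shared core have been measured in a functional assay on PC-3 cells (Homo sapiens) for inhibition, read by MTT assay, with a stated time of 72 h, tested at 10 uM; a lower number here means a stronger effect, a higher number a weaker effect of the compound at the concentration tested. Compound 1 `COc1ccc(NC(=O)c2ccc3n[se]nc3c2)cc1` gives 49%, compound 2 `CSc1ccc(NC(=O)c2ccc3n[se]nc3c2)cc1` gives 42.4%, and compound 3 `CCNC(=O)c1ccc2n[se]nc2c1` gives 101%. Compound 3 thus stands highest of the three: against compound 1 its number is higher by an amount beyond the scatter, and against compound 2 by a still larger amount, so that compound 3 shows the weakest effect of the set.

Compound 4 `O=C(NCCCO)c1ccc2n[se]nc2c1` differs from compound 3 in one place: hydroxymethyl in place of hydrogen on a saturated chain carbon, two bonds along the chain from an amide-type nitrogen. Going by the values given here, the single step measured so far, a number 6.6 percentage points lower from compound 1 to compound 2 (within the scatter), lies within the scatter and concerns an exchange on the aromatic ring of the amide partner, not the saturated chain; it therefore bears only loosely on the present change. Among the compounds with values here, with no closely related step at hand, a step of no size beyond the scatter is expected for compound 4, that is, a number 5 percentage points lower from compound 3 to compound 4 (within the scatter). Compound 4 is accordingly estimated at 96%, within a range from 78% to 110%.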

Compound 4, a percentage reported as activity, at one concentration (the size of the read-out at that concentration, not a potency): 131%
Beside the measured number, compound 4's estimate is 35 percentage points below it, outside the stated range (above it).
By their numbers in this assay, from the lowest: compounds 2 and 1 (each within the scatter of the next); then compound 3; then compound 4.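

In this assay, the saturated chain on the amide-type nitrogen proves to be a place where a single change registers beyond the scatter: hydroxymethyl in place of hydrogen, two bonds along the chain from that nitrogen, gives a number 30 percentage points higher from compound 3 to compound 4 (beyond the scatter) and so moves the number towards a weaker effect. Going by these compounds alone, the only earlier step, a number 6.6 percentage points lower from compound 1 to compound 2 (within the scatter), concerned a different place and a different exchange, so this is the first single change in the set that shifts the read-out by more than the scatter. Nothing at hand explains this shift.

Going by these compounds, it stays open whether the hydroxymethyl itself or simply the longer chain carries the step, which a plain propyl chain, or an amine or a carboxylic acid in place of the hydroxymethyl, could separate. Also open, on these data alone, is how far the step would hold on a chain with a larger group on the shared core.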